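A few compounds are considered here, and "the series" means these few. Any claim that something is new, unique, unknown or untested is made for them only; others in the source may bear on it.

Measured so far, in a functional assay on KBVIN cells (Homo sapiens) for cytotoxicity, read by MTT assay, with a stated time of 72 h; on this read-out lower numbers stand for an effect already at smaller amounts and higher numbers for an effect only at larger amounts of compound:

compound 1 `COc1cccc(Nc2cc(-c3ccccc3)oc(=O)c2)c1`, compound 1 gives 0.55 uM
compound 2 `O=c1cc(NC2CC2)cc(-c2ccccc2)o1`, compound 2 gives > 30 uM, which is a limit of the assay and not a number
compound 3 `COc1ccc(Nc2cc(C3CCCCC3)oc(=O)c2)cc1`, compound 3 gives 4.39 uM

Compound 2 stands at the edge of what this assay can report: its value is a limit, and it is the only one of the three that sits there (the limit of > 30 uM in this assay, at which 1 of the 3 values shown sits). Compound 1 and compound 3, which both carry an aromatic amine on the shared core, give numbers well inside the measurable range.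

Compound 4 `O=c1cc(Nc2ccccc2)cc(-c2ccccc2)o1` has not yet been measured. It differs from compound 2 in one place: phenyl in place of cyclopropyl on a nitrogen on an aromatic ring. Within the data shown here, no step between two measured compounds matches this change exactly, so the expectation rests on the broader picture. Compound 1 gives 0.55 uM and compound 3 gives 4.39 uM, and both carry a phenyl on that nitrogen, which suggests that replacing cyclopropyl with phenyl should move the value well beyond the scatter toward smaller amounts.

The expected step, an at least 20-fold lower number from compound 2 to compound 4 (1.30 log units; beyond the scatter), is therefore large and in the direction of stronger effect. Compound 4 is estimated at 1.5 uM, with a range from 0.4 uM to 6 uM.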

Compound 4, concentration for half-maximal effect: 0.15 uM
Estimate against measurement, compound 4: 10-fold (1.00 log units) above; measured number outside the range, below it.
By their numbers in this assay, from the lowest: compound 4; then compound 1; then compound 3. At a limit, above all of these: compound 2.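

In this assay, phenyl in place of cyclopropyl on a nitrogen on an aromatic ring can now be read as a change in one place, and it gives an at least 200-fold lower number from compound 2 to compound 4 (2.30 log units; beyond the scatter). That step has only a lower bound, since compound 2 stands at a limit of the assay and not at a number: the limit of > 30 uM in this assay, at which 1 of the 4 values shown sits. The phenyl needs no methoxy to reach this range, as hydrogen in place of methoxy on an aromatic carbon gives a 3.7-fold lower number from compound 1 to compound 4 (0.56 log units; beyond the scatter).

Compound 3 differs from each other compound in more than one place, so the effects of its cyclohexyl and its methoxy cannot be told apart. From the compounds shown here alone, how a fluorine or an amine on that phenyl would compare with hydrogen remains open, as does a benzyl on the nitrogen.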